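The source may report more compounds than this note shows. Statements on the series, on what has been measured and on what is new or still open speak of the compounds shown alone.

Compound 1 `N#Cc1c(NN)nc(SCc2nc3ccccc3[nH]2)nc1-c1ccccc1`: 5.4 nM. Compound 2 `N#Cc1c(Nc2ccccc2)nc(SCc2nc3ccccc3[nH]2)nc1-c1ccccc1`: 2.5 nM. Compound 3 `N#Cc1c(Nc2nccs2)nc(SCc2nc3ccccc3[nH]2)nc1-c1ccccc1`: 3.2 nM.

In a functional assay on NB1 cells (Homo sapiens) for cytotoxicity, read by MTT assay, with a stated time of 3 days (a lower number here means a stronger inhibitor, a higher number a weaker inhibitor), compound 3 stands second highest of the three numbers, within the scatter of both compound 2 and compound 1. Compound 4 `N#Cc1c(-c2ccccc2)nc(SCc2nc3ccccc3[nH]2)nc1N1CCNCC1` differs from compound 3 in one place: piperazin-1-yl in place of (1,3-thiazol-2-yl)amino on an aromatic carbon. The measured steps all vary the group on the nitrogen of the shared core: a 2.2-fold lower number from compound 1 to compound 2 (0.33 log units; beyond the scatter) was modest, while a 1.7-fold lower number from compound 1 to compound 3 (0.23 log units; within the scatter) and a 1.3-fold higher number from compound 2 to compound 3 (0.11 log units; within the scatter) lay within the scatter. None of them swaps the whole nitrogen-linked group for piperazin-1-yl, so they bear only loosely on this change; at most a modest step in this assay is expected, in either direction. The step is estimated as a 1.6-fold higher number from compound 3 to compound 4 (0.19 log units; within the scatter). Compound 4 is expected to give 5 nM, with a range from 1.5 nM to 20 nM.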

Compound 4, half-maximal inhibitory concentration: 6.75 nM
Estimate against measurement, compound 4: 1.4-fold (0.13 log units) below; the range from low to high includes it.
By their numbers in this assay, from the lowest: compounds 2, 3, 1 and 4 (each within the scatter of the next, the first and the last beyond it).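

In this assay, the position takes piperazin-1-yl, a non-aromatic ring, on the aromatic carbon at a modest cost against the aromatic amines, with a 2.1-fold higher number from compound 3 to compound 4 (0.32 log units; beyond the scatter) and a 2.7-fold higher number from compound 2 to compound 4 (0.43 log units; beyond the scatter). Against the aminoamino group, the same swap gives a 1.3-fold higher number from compound 1 to compound 4 (0.10 log units; within the scatter), so the change is read differently depending on the compound it is compared with. Nothing available accounts for these steps.

The compounds shown leave open what the second ring nitrogen of piperazin-1-yl contributes, which a morpholine or a methylpiperazine at this carbon would address.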